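The source may hold more compounds than are shown below. What is called first, only, known or untested is meant among the compounds shown, and "the series" means these compounds.

Compound 1, `CCc1ccccc1NC(=O)N[C@@H](C)c1ccccc1`, gives 100% in an ADME assay on the whole organism with Oryza sativa as the target, tested at 0.1 uM; a lower number here means a stronger effect, a higher number a weaker effect of the compound at the concentration tested. Compound 2, `CC(C)c1ccccc1NC(=O)N[C@H](C)c1ccccc1`, gives 103% in this assay, the higher of the two numbers, yet its gap to compound 1 lies within the scatter, so the two read as alike. Compound 3, `CC(C)c1ccccc1NC(=O)N[C@@H](C)c1ccccc1`, is to be measured; it differs from compound 2 in this way: the two compounds have the same atoms and bonds and differ only in configuration as drawn: 1 of 1 stereo elements differ; a stereocentre at a saturated chain carbon is drawn R in compound 2 and S in compound 3. Among the compounds with values here, no measured pair here shows a single change, so the step from compound 2 to compound 3 cannot be read from the data; compound 1 and compound 2 both sit near full activity. Compound 3 is therefore expected to show a number 3 percentage points lower from compound 2 to compound 3 (within the scatter), a step not beyond the scatter. The estimate for compound 3 is 100%, ranging from 85% to 115%.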

Compound 3, a percentage reported as activity, at one concentration (the size of the read-out at that concentration, not a potency): 99%
Beside the measured number, compound 3's estimate is 1 percentage points above it; the measured number falls inside the stated range.
By their numbers in this assay, from the lowest: compounds 3, 1 and 2 (each within the scatter of the next).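

In this assay, the drawn configuration at the stereocentre gives a number 4 percentage points lower from compound 2 to compound 3 (within the scatter), so compound 2 and compound 3 read as alike. Methyl in place of hydrogen on a saturated chain carbon bound to an aromatic carbon and a saturated chain carbon gives a number 1 percentage points lower from compound 1 to compound 3 (within the scatter), so compound 1 and compound 3 also read as alike. The first of these comparisons is a clean test of configuration alone: the fact that compounds 2 and 3 differ only in the configuration as drawn

The compounds shown leave open whether any change to the shared core would move this read-out beyond the scatter. Going by these compounds, an amine or a carboxylic acid in place of the alkyl group remains untested here.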